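Swapping the amide tail of compound 3 for an aminobutyl chain

The compounds below may be only part of what the source reports. "The series", "measured", "known", "first", "only" and "open" are said of these compounds alone.

Measured compounds:
Compound 1, `O=C(Nc1ccc(S(=O)(=O)N2CCCCC2)c2ccccc12)c1ccccc1`, in an assay on L1.2 cells for binding affinity to C-C chemokine receptor type 8 (Homo sapiens) (on this read-out lower numbers stand for stronger inhibition and higher numbers for weaker inhibition), gives > 30000 nM, which is a limit of this assay, not a number.
Compound 2, `CCOC(=O)N1CCC(NS(=O)(=O)c2ccc(O)c3ccccc23)CC1`, in this assay gives > 5000 nM, again a limit.
Compound 3, `Cc1ccccc1C(=O)Nc1ccc(S(=O)(=O)NC2CCN(C(=O)C3CCCC3)CC2)c2ccccc12`, in this assay gives 9.1 nM.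

Going by the values given here, compound 3 thus provides the only actual number among the three; the other two stop at limits, the limit of > 30000 nM in this assay, at which 1 of the 3 values shown sits, and (the limit of > 5000 nM in this assay, at which 1 of the 3 values shown sits).

Compound 4, `Cc1ccccc1C(=O)Nc1ccc(S(=O)(=O)NC2CCN(C(=O)CCCCN)CC2)c2ccccc12`, differs from compound 3 in one spot: 4-aminobutyl in place of cyclopentyl on a carbonyl carbon. Among the compounds with values here, no measured pair shows this kind of exchange, so the direction and size of the step rest on expectation alone. A modest loss beyond the scatter is expected, the step from compound 3 to compound 4 being estimated at a 4.4-fold higher number from compound 3 to compound 4 (0.64 log units; beyond the scatter). Compound 4 is expected at 40 nM, within 8 nM to 200 nM.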

Compound 4, inhibition constant: 199 nM
Beside the measured number, compound 4's estimate is 5.0-fold (0.70 log units) below it, within the range that was stated.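

In this assay, going by these compounds alone, putting 4-aminobutyl in place of cyclopentyl on a carbonyl carbon gives a 22-fold higher number from compound 3 to compound 4 (1.34 log units; beyond the scatter) and is the first measured step at this position. The number shows that this position responds strongly to the exchange, even though both groups have the same heavy-atom count, yet compound 4 still gives 199 nM, a true number and not a limit. Nothing measured here explains the rise. Still open, on these data alone, is whether losing the ring or gaining the amine matters more: a plain pentyl chain, or a cyclopentyl ring carrying an amine, would separate the two.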